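The source may report more compounds than this note shows. Statements on the series, on what has been measured and on what is new or still open speak of the compounds shown alone.

Compound 1 `COc1cc2cc(Oc3ccc(NC(=O)Nc4ccccc4)cc3)c(C)nc2cc1OC`: in a functional assay on M14 cells (Homo sapiens) for inhibition, read by sulforhodamine B assay, with a stated time of 48 h, tested at 10 uM (a higher number here means a weaker effect of the compound at the concentration tested, a lower number a stronger effect), compound 1 gives 93.7%.
Compound 2 `COc1cc2cc(Oc3ccc(NC(=O)Nc4ccc(C)cc4)cc3)c(C)nc2cc1OC`: in this assay compound 2 gives 124%.

For the measured compounds named here, compound 2 holds the highest of the two numbers; the one step measured, a number 30.3 percentage points higher from compound 1 to compound 2 (beyond the scatter), sets it apart from compound 1. Compound 3 `COc1cc2cc(Oc3ccc(NC(=O)Nc4ccc(C(F)(F)F)cc4)cc3)c(C)nc2cc1OC` differs from compound 2 by trifluoromethyl in place of methyl on an aromatic carbon. Going by the values given here, no measured step matches this change: the step from hydrogen to methyl on an aromatic carbon was large, yet it says nothing about how trifluoromethyl compares with methyl. With nothing closer to go on, a step of a number 16 percentage points lower from compound 2 to compound 3 (beyond the scatter) is expected, not beyond the scatter. For compound 3 the estimate in this assay is 108%, from 80% to 135%.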

Compound 3, a percentage reported as activity, at one concentration (the size of the read-out at that concentration, not a potency): 95.2%
For compound 3 the middle estimate is 12.8 percentage points above the measured one, within the range that was stated.
By their numbers in this assay, from the lowest: compounds 1 and 3 (each within the scatter of the next); then compound 2.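

In this assay the change at this aromatic carbon, para to a large group, shows a number 28.8 percentage points lower from compound 2 to compound 3 (beyond the scatter) when trifluoromethyl replaces methyl, and a number 1.5 percentage points higher from compound 1 to compound 3 (within the scatter) when trifluoromethyl replaces hydrogen. The higher number seen with methyl is therefore not shared by every group placed here, and trifluoromethyl leaves the read-out level with the unsubstituted compound 1. No measurement is available that explains this difference between the two groups. On these data alone, how a chlorine, a methoxy group or an amine at this carbon would compare remains open.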